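This account rests on a few compounds, and the source may have more. Where it says the series, first, only, none or still open, it means among the compounds named here.

The compounds were tested in a functional assay on HL-60 cells (Homo sapiens) for antiproliferative activity; a lower number here means a stronger inhibitor, a higher number a weaker inhibitor. Three of them have measured results, each of which is a limit of the assay rather than a number:

Compound 1 `COC(=O)c1cccc(Oc2ccc(OC)cc2)c1`: in this assay compound 1 gives > 20000 nM, a limit.
Compound 2 `COC(=O)c1cccc(Oc2ccc(OC)c(F)c2)c1`: in this assay compound 2 gives > 20000 nM, a limit.
Compound 3 `CCOC(=O)c1ccc(Oc2ccc(OC)cc2)cc1O`: in this assay compound 3 gives > 30000 nM, a limit.

Compound 1 and compound 2 differ in one place, (fluoro in place of hydrogen on an aromatic carbon). Because both results sit at the limit of > 20000 nM in this assay, at which 2 of the 3 values shown sit, the step that the two limits leave unreadable from compound 1 to compound 2 cannot be read: the change could have helped, hurt or done nothing, and the assay would not show it. Compound 3 rests on a different core, and the difference between the two cores is not broken down here. Its result sits at the limit of > 30000 nM in this assay, at which 1 of the 3 values shown sits, which again says nothing beyond the limit.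

Compound 4 `CCOC(=O)c1ccc(Oc2ccc(OC)c(F)c2)cc1O` has not yet been measured. It stands to compound 3 as compound 2 stands to compound 1: the change is fluoro in place of hydrogen on an aromatic carbon, and since the two place descriptions agree word for word, it is the same change. For the measured compounds named here, with nothing readable from the earlier pair, the expected step from compound 3 to compound 4, a number no higher from compound 3 to compound 4 (the limit leaves the size open), is small, because the only comparable step that the two limits leave unreadable from compound 1 to compound 2 is itself unreadable and offers no reason to expect movement. For compound 4 the estimate is therefore 30000 nM, most likely reported again only as a limit.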

Compound 4, half-maximal inhibitory concentration: > 30000 nM
Compound 4: no number, only a limit; the forecaster's own chance of this, stated with the estimate: 80%; the middle value lies on the limit itself.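

In this assay compound 4 gives > 30000 nM, which is a limit and not a number. Compound 3 and compound 4 therefore give no readable step, as both sit at the same limit: the limit of > 30000 nM in this assay, at which 2 of the 4 values shown sit.

The compounds shown leave open whether fluoro in place of hydrogen on an aromatic carbon changes the activity at all, and how strong any of the four compounds truly is.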